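A few compounds are considered here, and "the series" means these few. Any claim that something is new, unique, unknown or untested is made for them only; others in the source may bear on it.

Measured so far in an ADME assay on L1210/0 cells (Mus musculus) for cytotoxicity, with a stated time of 48 h; on this read-out higher numbers stand for weaker inhibition and lower numbers for stronger inhibition:

compound 1, `OC[C@@H]1C[C@H](Cn2cnc3c(NC4CC4)ncnc32)c2c(-c3ccccc3)nnc(-c3ccccc3)c21`: > 200000 nM
compound 2, `N#CSc1cn([C@H]2C[C@H](O)[C@@H](CO)O2)c(=O)[nH]c1=O`: 78900 nM
compound 3, `Cc1cn(C[C@@H]2C[C@H](CO)c3ccccc32)c(=O)[nH]c1=O`: > 200000 nM

The value for compound 1 is a limit of this assay, not a number. The value for compound 3 is likewise a limit. Within the data shown here, compound 2 therefore holds the only number in this assay; the other two values sit at the limit, as the limit of > 200000 nM in this assay, at which 2 of the 3 values shown sit, records. Among the measured compounds shown here, no two measured compounds differ in a single place, so no step between measured compounds can be set out, and the three values cannot be ranked against each other beyond noting that compound 2 alone returned a number.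

Compound 4, `C#COc1cn([C@H]2C[C@H](O)[C@@H](CO)O2)c(=O)[nH]c1=O`, is still to be measured in this assay. It arises from compound 2 by ethynyloxy in place of cyanosulfanyl on an aromatic carbon. The rest of the molecule is kept as it is.

For the measured compounds named here, with no measured step to draw on, the expected step in this assay from compound 2 to compound 4 is small, without a firm direction, and likely within the usual scatter; a drift toward weaker inhibition and a limit cannot be excluded given how close compound 2 already lies to the limit shared by compound 1 and compound 3. The estimate for compound 4 is 100000 nM, between 25000 nM and 400000 nM, which means an expected step of a 1.3-fold higher number from compound 2 to compound 4 (0.10 log units; within the scatter).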

Compound 4, half-maximal inhibitory concentration: > 200000 nM
Compound 4: a limit, no number (the forecaster's own chance of this, stated with the estimate: 35%); middle value at least 2.0-fold (0.30 log units) from the limit.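

In this assay, among these compounds, ethynyloxy in place of cyanosulfanyl on an aromatic carbon gives the first single-place comparison: an at least 2.5-fold higher number from compound 2 to compound 4 (0.40 log units; beyond the scatter). Compound 4 gives > 200000 nM, which is a limit of the assay and not a number, so the step has a lower bound but no measured size. The two groups match in heavy-atom count and each holds one triple bond outside aromatic rings, yet this position separates them, with the number seen for compound 2 lost in the exchange and compound 4 joining the values at the limit: the limit of > 200000 nM in this assay, at which 3 of the 4 values shown sit.

Among the compounds shown here, whether the number for compound 2 depends on the sulfur, the nitrile or the intact cyanosulfanyl group stays open, and the single step gives no cause and no trend for this position. A methylsulfanyl group, a nitrile set directly on the ring or an amine on the same aromatic carbon would help separate these possibilities, and any of them returning a number would show how much room this position has in this assay.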